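Working notes: methyl for fluoro in compound 4

The source may hold more compounds than are shown below. What is called first, only, known or untested is meant among the compounds shown, and "the series" means these compounds.

In an assay on HeLa cells for inhibition of Indoleamine 2,3-dioxygenase 1 (Homo sapiens), read by spectrophotometry, with a stated time of 24 h (on this read-out lower numbers stand for an effect already at smaller amounts and higher numbers for an effect only at larger amounts of compound), compound 1 `CC(=O)Nc1ccc(S(=O)(=O)NNc2ccccc2)cc1` gives only a limit, > 10000 nM, as recorded under (the limit of > 10000 nM in this assay, at which 1 of the 3 values shown sits). Compound 2 `CC(=O)Nc1ccc(S(=O)(=O)NNc2ccc(Br)cc2)cc1` gives 85 nM in this assay. Compound 3 `CC(=O)Nc1ccc(S(=O)(=O)NNc2ccc(Br)c(F)c2)cc1` gives 187 nM and so stands highest of the two numbers shown; the step of a 2.2-fold higher number from compound 2 to compound 3 (0.34 log units; beyond the scatter) separates it from the nearest number.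

Compound 4 `CC(=O)Nc1ccc(S(=O)(=O)NNc2ccc(Br)c(C)c2)cc1` differs from compound 3 by methyl in place of fluoro on an aromatic carbon. The step bearing on this exchange is the one that introduced the fluoro, a 2.2-fold higher number from compound 2 to compound 3 (0.34 log units; beyond the scatter), which was modest; the large step of an at least 110-fold lower number from compound 1 to compound 2 (2.07 log units; beyond the scatter) concerns the bromo and is not touched here. For the measured compounds named here, no measured step shows a methyl, so the expected step is a 1.0-fold lower number from compound 3 to compound 4 (0.02 log units; within the scatter), not beyond the scatter. Compound 4 is therefore estimated at 180 nM, with a range of 70 nM to 500 nM.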

Compound 4, half-maximal effective concentration: 130 nM
Compound 4: the middle estimate sits 1.4-fold (0.14 log units) above what was measured; measured number inside the range.
By their numbers in this assay, from the lowest: compounds 2, 4 and 3 (each within the scatter of the next, the first and the last beyond it). At a limit, above all of these: compound 1.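

At the position ortho to the bromo group, the exchange gives a 1.4-fold lower number from compound 3 to compound 4 (0.16 log units; within the scatter) in this assay and so does not separate methyl from fluoro. Methyl in place of hydrogen gives a 1.5-fold higher number from compound 2 to compound 4 (0.18 log units; within the scatter) and stays within the scatter, while fluoro in place of hydrogen gives a 2.2-fold higher number from compound 2 to compound 3 (0.34 log units; beyond the scatter) and lies just beyond it. Nothing measured here bears on why these groups behave alike at this position.

On these data alone, whether a longer chain such as ethyl, or an amine, at this position would stay within the scatter of compound 2 remains open. Also open, as far as these compounds go, is whether methyl would have any effect here without the bromo group.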